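The source may hold more compounds than are shown below. What is called first, only, known or untested is meant among the compounds shown, and "the series" means these compounds.

Measured compounds:
- compound 1, `CCCCCCCCCCCCCCCCCCNC(=O)[C@@H]1CSC(c2ccc(OC)cc2)N1`: 8700 nM
- compound 2, `CCCCCCCCCCCCCCCCCCNC(=O)[C@@H]1CSC(c2cc(OC)c(OC)c(OC)c2)N1`: 3900 nM
- compound 3, `CCCCCCCCCCCCCCCCCCNC(=O)[C@@H]1CSC(c2ccc(O)cc2)N1`: 3100 nM

All three were tested in a functional assay on DU-145 cells (Homo sapiens) for antiproliferative activity, read by sulforhodamine B assay; on this read-out higher numbers stand for weaker inhibition and lower numbers for stronger inhibition. Compound 3 has the lowest of the three numbers, but its position is uneven: against compound 1 the gap is a 2.8-fold lower number from compound 1 to compound 3 (0.45 log units; beyond the scatter), which lies beyond the scatter, whereas against compound 2 the gap is only a 1.3-fold lower number from compound 2 to compound 3 (0.10 log units; within the scatter), which lies within it, so compound 3 and compound 2 cannot be ordered.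

Compound 4, `CCCCCCCCCCCCCCCCCCNC(=O)[C@@H]1CSC(c2c(OC)cc(OC)cc2OC)N1`, has not yet been measured. It differs from compound 3 in one place: 2,4,6-trimethoxyphenyl in place of 4-hydroxyphenyl on a saturated ring carbon.

Among the measured compounds shown here, two measured steps bear on this change. The step of a 2.2-fold lower number from compound 1 to compound 2 (0.35 log units; beyond the scatter) shows what adding methoxy groups to the phenyl did once. The step of a 1.3-fold lower number from compound 2 to compound 3 (0.10 log units; within the scatter) shows that a trimethoxyphenyl and a 4-hydroxyphenyl gave numbers within the scatter of each other. Nothing measured addresses the 2,4,6-trimethoxyphenyl itself. The author therefore expects the step of a 1.5-fold higher number from compound 3 to compound 4 (0.16 log units; within the scatter) to be small, most likely within the scatter, with a slight lean toward a higher number in this assay because of a 1.3-fold lower number from compound 2 to compound 3 (0.10 log units; within the scatter). The estimate for compound 4 is 4500 nM, within the range 1800 nM to 11000 nM.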

Compound 4, half-maximal inhibitory concentration: 7300 nM
The estimate for compound 4 lay 1.6-fold (0.21 log units) below the measured number; low and high end bracket the measured number.
By their numbers in this assay, from the lowest: compounds 3, 2, 4 and 1 (each within the scatter of the next, the first and the last beyond it).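

In this assay, 2,4,6-trimethoxyphenyl in place of 4-hydroxyphenyl on the saturated ring carbon gives a step beyond the scatter (a 2.4-fold higher number from compound 3 to compound 4 (0.37 log units; beyond the scatter)), so this position does not treat every substituted phenyl alike, something the step between the 3,4,5-trimethoxyphenyl and the 4-hydroxyphenyl could not show. The 2,4,6-trimethoxyphenyl cannot be told apart from the 3,4,5-trimethoxyphenyl (a 1.9-fold higher number from compound 2 to compound 4 (0.27 log units; within the scatter)) or from the 4-methoxyphenyl (a 1.2-fold lower number from compound 1 to compound 4 (0.08 log units; within the scatter)), so compound 4 lies within the scatter of both compound 1 and compound 2, although those two lie beyond the scatter of each other. The lower number that came with the 3,4,5-trimethoxyphenyl is therefore not shown to extend to the other trimethoxyphenyl, and compound 4 leaves it tied to compound 2 alone.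

The compounds shown leave open how a phenyl carrying a dimethylamino group or a carboxylic acid would read at this position, and whether a 2,4,6-trihydroxyphenyl would follow the 4-hydroxyphenyl or the 2,4,6-trimethoxyphenyl. Why the 4-hydroxyphenyl and the 2,4,6-trimethoxyphenyl differ also stays open, as no measurement at hand speaks to it.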